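This account rests on a few compounds, and the source may have more. Where it says the series, first, only, none or still open, it means among the compounds named here.

The measured compounds:

Compound 1 `Cc1c(OCCCCOc2ccccc2C(=O)O)ccc(C(=O)CC2CCCC2)c1O`: in an assay on HEK293 cells for positive allosteric modulation of metabotropic glutamate receptor 3 (Rattus norvegicus), read by thallium flux, with a stated time of 2.5 min (a higher number here means a larger maximal response, a lower number a smaller maximal response), compound 1 gives 32.9%.
Compound 2 `Cc1cc(OCCCCOc2ccc(C(=O)CC3CCCC3)c(O)c2C)ccc1C(=O)O`: in this assay compound 2 gives 23.7%.

Compound 2 is one of two compounds with a number in this assay. Within the data shown here, its only neighbour is compound 1, and the gap between them is a number 9.2 percentage points lower from compound 1 to compound 2 (within the scatter), so the two compounds are not told apart by these measurements.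

Compound 3 `Cc1c(OCCCCOc2ccc(F)c(C(=O)O)c2)ccc(C(=O)CC2CCCC2)c1O` has not yet been measured. It differs from compound 2 in one place: 3-carboxy-4-fluorophenyl in place of 4-carboxy-3-methylphenyl on an oxygen on a saturated carbon

Among the measured compounds shown here, the single measured step that bears on this change is the one from compound 1 to compound 2, where the group on the same oxygen on a saturated carbon was exchanged and the result was a number 9.2 percentage points lower from compound 1 to compound 2 (within the scatter), a step inside the scatter. The exchange leading to compound 3 is of the same kind, a change of the substituents on the aryl group carrying the carboxylic acid, so no movement beyond the scatter is expected in this assay, in either direction.

For compound 3 the estimated step is a number 3.3 percentage points higher from compound 2 to compound 3 (within the scatter). Compound 3 is therefore expected to give about 27%, between 12% and 42%.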

Compound 3, largest response reached (reported as percent of maximum), in percent of the reference or control that the assay uses: 98.4%
The estimate for compound 3 lay 71.4 percentage points below the measured number, and the stated range ends below it.
By their numbers in this assay, from the lowest: compounds 2 and 1 (each within the scatter of the next); then compound 3.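

In this assay, the 3-carboxy-4-fluorophenyl group on this oxygen gives a number 74.7 percentage points higher from compound 2 to compound 3 (beyond the scatter), and set against the 2-carboxyphenyl group it gives a number 65.5 percentage points higher from compound 1 to compound 3 (beyond the scatter). The aryl group carrying the carboxylic acid is therefore not a place where exchanges leave the maximal response unchanged, even though compound 1 and compound 2 could not be told apart, and compound 3 stands clearly above both of them. No measurement shown accounts for the size of these steps.

Each step changes more than one feature at once, since the carboxylic acid sits at a different ring position in all three compounds and the fluorine enters as well, so the shares of the two features in the rise cannot be separated. Going by these compounds, whether a 3-carboxyphenyl group without fluorine would keep the response stays open, as does what a chlorine in place of that fluorine, or a tetrazole or an amide in place of the carboxylic acid, would do to it.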